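Chloro on the phenyl of a sulfamide series

The source may report more compounds than this note shows. Statements on the series, on what has been measured and on what is new or still open speak of the compounds shown alone.

Compound 1 is `NS(=O)(=O)NCC1CCN(c2cc(-c3ccccc3)ncn2)CC1`. In a functional assay on M21 cells (Homo sapiens) for antiproliferative activity, read by sulforhodamine B assay, with a stated time of 48 h (a lower number here means a stronger inhibitor of growth, a higher number a weaker inhibitor of growth), compound 1 gives > 100000 nM, a limit of the assay.
Compound 2 is `NS(=O)(=O)NCCC1CCN(c2cc(-c3ccccc3)ncn2)CC1`. In this assay compound 2 gives > 100000 nM, also a limit of the assay.

Compound 2 therefore stands at the limit, with no number of its own; the step that the two limits leave unreadable from compound 1 to compound 2 is unreadable for the same reason, and the limit of > 100000 nM in this assay, at which 2 of the 2 values shown sit, describes both values shown. Compound 3 is `NS(=O)(=O)NCCC1CCN(c2cc(-c3ccc(Cl)cc3)ncn2)CC1`. It differs from compound 2 by chloro in place of hydrogen on an aromatic carbon. Among the measured compounds shown here, no measured step bears on that change, and the only step present gives no size, so nothing here predicts a shift beyond the scatter in this assay in either direction. Compound 3 is expected to sit at the limit as well, estimated at 100000 nM (range 30000 nM to 300000 nM). The step of a number no higher from compound 2 to compound 3 (the limit leaves the size open) is thus expected to be none beyond the scatter.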

Compound 3, concentration for 50% growth inhibition: 45200 nM
Beside the measured number, compound 3's estimate is 2.2-fold (0.34 log units) above it; the range from low to high includes it.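

In this assay, 4-chlorophenyl in place of phenyl gives an at least 2.2-fold lower number from compound 2 to compound 3 (0.34 log units; beyond the scatter). Among the compounds shown here, with 45200 nM, compound 3 is the first compound here with a number of its own, so a change at this ring carbon can bring the series within the readable range, something the earlier pair could not show, as its step cannot be read. The full size of the step stays open because its starting point is a limit: the limit of > 100000 nM in this assay, at which 2 of the 3 values shown sit.

On these data alone, whether this shift is particular to chloro, or would also follow from fluoro, methoxy or an amine on the same carbon, remains open. Also open, as far as these compounds go, is whether chloro at this position would give a readable number on the chain of compound 1.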